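Carbonyl to sulfonyl on the ring nitrogen: expected tolerance

This account rests on a few compounds, and the source may have more. Where it says the series, first, only, none or still open, it means among the compounds named here.

Compound 2 `O=C(Nc1ncc(C(Oc2ccc3cc(Br)ccc3c2)c2ccc(Cl)cc2)s1)c1ccc(F)cc1Br` is one of two compounds with a reading in an ADME assay on HepG2 2.2.15 cells (Homo sapiens) for cytotoxicity; a higher number here means that more compound is tolerated, a lower number that less compound is tolerated. Compound 2 reaches only a limit of the assay there, > 50000 nM, so no single number exists for it. Compound 1 `COCCNc1ncc(C(Oc2ccc3cc(Br)ccc3c2)c2ccc(Cl)cc2)s1` is recorded in this assay as "not toxic" (no number reported), also without a number. The only numerical entry is thus (the limit of > 50000 nM in this assay, at which 1 of the 2 values shown sits). Compound 3 `O=S(=O)(Nc1ncc(C(Oc2ccc3cc(Br)ccc3c2)c2ccc(Cl)cc2)s1)c1ccc(Cl)cc1` changes one group: (4-chlorophenyl)sulfonyl in place of (2-bromo-4-fluorophenyl)carbonyl on a nitrogen on an aromatic ring. Among the measured compounds shown here, no measured step between compounds exists to guide the size of this change, so no shift beyond the usual scatter is expected. Compound 3 is estimated at 50000 nM, with a range from 20000 nM to 120000 nM. The expected step is a number no higher from compound 2 to compound 3 (the limit leaves the size open), within the scatter.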

Compound 3, half-maximal cytotoxic concentration: "not toxic" (no number reported)
Compound 3 has no reported number here, so the estimate cannot be set against anything.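

No step can be read from compound 2 to compound 3, since neither has a single number: the limit of > 50000 nM in this assay, at which 1 of the 3 values shown sits. Going by these compounds, how much compound any of the three compounds tolerates before cells suffer stays open, and so does the effect of the carbonyl-to-sulfonyl swap.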